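Geometry of the exocyclic double bond in compound 1

The source may hold more compounds than are shown below. What is called first, only, known or untested is meant among the compounds shown, and "the series" means these compounds.

Measured compounds:
- compound 1 `C=C(Br)C(=O)Nc1ccc2c(c1)/C(=C/c1cccs1)C(=O)N2`: 35 nM
- compound 2 `Nc1ccc2c(c1)C(=Cc1ccsc1)C(=O)N2`: > 10000 nM

For the measured compounds named here, in a functional assay on CCRF-CEM cells (Homo sapiens) for antiproliferative activity, read by MTT assay, with a stated time of 72 h (a higher number here means a weaker inhibitor, a lower number a stronger inhibitor), compound 1 gives 35 nM and is the only compound with a numerical value. Compound 2 reaches only the limit of the assay, at > 10000 nM, which is a limit rather than a number; this is the situation described by the limit of > 10000 nM in this assay, at which 1 of the 2 values shown sits. Going by the values given here, no step between two measured compounds is available, so nothing can be read off about how geometry changes potency.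

Compound 3 `C=C(Br)C(=O)Nc1ccc2c(c1)/C(=C\c1cccs1)C(=O)N2` differs from compound 1 as follows: the two compounds have the same atoms and bonds and differ only in configuration as drawn: 1 of 1 stereo elements differ; a double bond is drawn Z in compound 1 and E in compound 3. Since only the drawn configuration changes, the shape presented by the thiophene arm differs. The step from compound 1 to compound 3 is expected to weaken potency moderately, estimated as a 4.3-fold higher number from compound 1 to compound 3 (0.63 log units; beyond the scatter), with wide uncertainty. Compound 3 is therefore expected to give about 150 nM, within 30 nM to 1500 nM.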

Compound 3, half-maximal inhibitory concentration: 710 nM
Compound 3: the middle estimate sits 4.7-fold (0.68 log units) below what was measured; the range from low to high includes it.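

In this assay, for the compounds shown here, the first step between two measured compounds is a 20-fold higher number from compound 1 to compound 3 (1.31 log units; beyond the scatter), which shows that the drawn configuration of the exocyclic double bond matters at this position, with the Z form in compound 1 the stronger of the pair. The size of this step can be assigned to the geometry alone: the fact that compounds 1 and 3 differ only in the configuration as drawn. Compound 3 still gives 710 nM, a numerical value, so the E form lowers potency here without removing it.

From the compounds shown here alone, whether the Z form keeps this advantage when an amine or a carboxylic acid is carried on the thiophene arm remains open. Going by these compounds alone, no step links compound 2 to compound 1 or compound 3, so what the amide arm contributes cannot be read from these compounds.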